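Trading a fused ring for a small thiadiazole on the sulfur

The source may hold more compounds than are shown below. What is called first, only, known or untested is meant among the compounds shown, and "the series" means these compounds.

Measured compounds:
compound 1 `Cn1c(-c2ccc(NC(=O)CCl)cc2)nc(-c2ccccc2)c1-c1ccccc1` gives 3.4%
compound 2 `Cn1c(-c2ccc(NC(=O)CSc3nc4ccccc4o3)cc2)nc(-c2ccccc2)c1-c1ccccc1` gives 18.7%
compound 3 `Cn1c(-c2ccc(NC(=O)CSc3nc4ccccc4s3)cc2)nc(-c2ccccc2)c1-c1ccccc1` gives 0.9%

All three were tested in a functional assay on MCF7 cells (Homo sapiens) for cytotoxicity, read by MTT assay, with a stated time of 24 h, tested at 0.64 ug/mL; on this read-out higher numbers stand for a stronger effect at the one concentration tested and lower numbers for a weaker effect. Compound 3 and compound 1 lie within the scatter of each other, as a number 2.5 percentage points lower from compound 1 to compound 3 (within the scatter) shows, while compound 2 sits apart: a number 15.3 percentage points higher from compound 1 to compound 2 (beyond the scatter) and a number 17.8 percentage points lower from compound 2 to compound 3 (beyond the scatter) are both beyond the scatter, so compound 3 is clearly under compound 2 but not separable from compound 1.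

Compound 4 `Cc1nnc(SCC(=O)Nc2ccc(-c3nc(-c4ccccc4)c(-c4ccccc4)n3C)cc2)s1` has not been measured. It differs from compound 3 by 5-methyl-1,3,4-thiadiazol-2-yl in place of 1,3-benzothiazol-2-yl on a sulfur. Going by the values given here, the one step that changes the same place is a number 17.8 percentage points lower from compound 2 to compound 3 (beyond the scatter), a modest move, and it ran from one fused ring to another; no measured step replaces a fused ring with a single five-membered ring, so the direction is open. Since compound 3 is already near the floor of this read-out, a small upward or flat step is expected. Compound 4 is estimated at 6%, between 0% and 20%, meaning an expected step of a number 5.1 percentage points higher from compound 3 to compound 4 (within the scatter) in this assay.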

Compound 4, a percentage reported as activity, at one concentration (the size of the read-out at that concentration, not a potency): 35.1%
For compound 4 the middle estimate is 29.1 percentage points below the measured one; the whole stated range lies below it.
By their numbers in this assay, from the lowest: compounds 3 and 1 (each within the scatter of the next); then compound 2; then compound 4.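

In this assay, this sulfur position proves able to carry a large change (a number 34.2 percentage points higher from compound 3 to compound 4 (beyond the scatter)), whereas the earlier swap of one fused ring for another gave only a modest step. The single five-membered ring also beats the other fused ring (a number 16.4 percentage points higher from compound 2 to compound 4 (beyond the scatter)) and the chloro compound (a number 31.7 percentage points higher from compound 1 to compound 4 (beyond the scatter)), so among these compounds a fused ring on the sulfur is not needed for a high number, and the smaller 5-methyl-1,3,4-thiadiazol-2-yl gives the highest one. Nothing shown here offers a reason for these steps.

The compounds shown do not separate the share of the methyl group from that of the thiadiazole ring itself. They also leave open what a simple amine or a carboxylic acid would do in place of that ring on this sulfur.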